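The source may report more compounds than this note shows. Statements on the series, on what has been measured and on what is new or still open speak of the compounds shown alone.

For the measured compounds named here, in a functional assay for agonist activity, with Homo sapiens as the target (a higher number here means a weaker inhibitor, a lower number a stronger inhibitor), compound 1 (`O=C(O)C[C@H](NC(=O)CN1CCc2ccc(N3CCNCC3)cc2C1=O)c1cccnc1`) gives 13 nM, the lower of the two numbers measured so far, while compound 2 (`O=C(CN1CCc2ccc(N3CCNCC3)cc2C1=O)NCC(NS(=O)(=O)c1ccccc1)C(=O)O`) gives 140 nM. Compound 3 (`O=C(O)C[C@H](NC(=O)CN1CCc2ccc(-c3c[nH]cn3)cc2C1=O)c1cccnc1`) keeps the core of compound 1 but carries 1H-imidazol-4-yl in place of piperazin-1-yl on an aromatic carbon. Going by the values given here, no measured pair shows this change, so the expectation is tentative. The expected change is a rise in this assay beyond the scatter, an estimated 23-fold higher number from compound 1 to compound 3 (1.36 log units; beyond the scatter). For compound 3 the estimated value is 300 nM, with an expected range from 50 nM to 2000 nM.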

Compound 3, half-maximal inhibitory concentration: 320 nM
The estimate for compound 3 lay 1.1-fold (0.03 log units) below the measured number; measured number inside the range.
By their numbers in this assay, from the lowest: compound 1; then compound 2; then compound 3.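

In this assay, exchanging piperazin-1-yl for 1H-imidazol-4-yl on the aromatic carbon gives a 25-fold higher number from compound 1 to compound 3 (1.39 log units; beyond the scatter). For the compounds shown here, compound 1 and compound 2 both carry piperazin-1-yl, so this is the first sign that the number responds to the group at this position, and a five-membered aromatic ring does not match the six-membered non-aromatic ring here. No measurement at hand accounts for the size of this step.

The compounds shown leave open whether piperidin-4-yl or an open-chain amine at this position would keep the lower number. They also leave open whether the same exchange would have a similar effect in compound 2.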